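This account rests on a few compounds, and the source may have more. Where it says the series, first, only, none or still open, it means among the compounds named here.

Measured compounds:
- compound 1, `CC1(C)C=C(n2ccccc2=O)c2cc(C(=O)c3cccs3)ccc2O1`: 5.84
- compound 2, `CC1(C)C=C(n2ccccc2=O)c2cc(C(=O)c3ccco3)ccc2O1`: 5.92
- compound 3, `CC1(C)C=C(n2ccccc2=O)c2cc(C(=O)c3ccccc3F)ccc2O1`: 6.34

These three share one core and differ only in the group attached to the carbonyl carbon. In a functional assay (trachea) with Rattus norvegicus as the target (a higher number here means a more potent compound, by a factor of ten per unit of this negative logarithm, a lower number a less potent compound), compound 1 gives 5.84, the lowest of the three numbers. The step of a number 0.08 log units higher from compound 1 to compound 2 (within the scatter) lies within the scatter, so compounds 1 and 2 cannot be told apart. The step of a number 0.50 log units higher from compound 1 to compound 3 (beyond the scatter) is a modest gain beyond the scatter, as is a number 0.42 log units higher from compound 2 to compound 3 (beyond the scatter).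

Compound 4, `CC1(C)C=C(n2ccccc2=O)c2cc(C(=O)c3c(F)cccc3F)ccc2O1`, has not yet been measured. It differs from compound 1 as follows: 2,6-difluorophenyl in place of thiophen-2-yl on a carbonyl carbon. The closest measured guide is the step from compound 1 to compound 3, where 2-fluorophenyl replaced thiophen-2-yl and gave a number 0.50 log units higher from compound 1 to compound 3 (beyond the scatter). Going by the values given here, no measured pair shows what a second fluorine on the phenyl ring adds, so the expectation for compound 4 rests on that one step alone, with added uncertainty. Compound 4 is therefore expected to land near compound 3, a step of about a number 0.56 log units higher from compound 1 to compound 4 (beyond the scatter), estimated at 6.4 with a range from 5.9 to 6.9.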

Compound 4, logarithm of the reciprocal of the active concentration, log(1/C): 5.99
For compound 4 the middle estimate is 0.41 log units above the measured one; low and high end bracket the measured number.
By their numbers in this assay, from the lowest: compounds 1, 2 and 4 (each within the scatter of the next); then compound 3.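

On this carbonyl carbon, more fluorine does not simply mean more potency: replacing one more hydrogen on the aromatic ring with fluoro gives a number 0.35 log units lower from compound 3 to compound 4 (beyond the scatter) in this assay. The 2,6-difluorophenyl group therefore loses the lead that 2-fluorophenyl held over the two five-membered rings, since the steps of a number 0.15 log units higher from compound 1 to compound 4 (within the scatter) and a number 0.07 log units higher from compound 2 to compound 4 (within the scatter) leave compound 4 indistinguishable from both thiophen-2-yl and furan-2-yl. Nothing available accounts for this loss of potency with the second fluorine.

The compounds shown leave open how a plain phenyl ring with no fluorine would compare on this carbonyl carbon, so the contribution of the first fluorine cannot be separated from that of the ring itself. They also do not show how a phenyl ring carrying a methoxy group or an amine would behave here.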